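From Compound 1 to Compound 3: One Aryl Group Exchanged

The source may hold more compounds than are shown below. What is called first, only, known or untested is meant among the compounds shown, and "the series" means these compounds.

In a functional assay on QGY-7703 cells (Homo sapiens) for cytotoxicity, read by MTT assay, with a stated time of 24 h (a higher number here means a weaker inhibitor, a lower number a stronger inhibitor), compound 1 `COc1cc(/C=C2\CN(S(=O)(=O)c3ccc(F)cc3)C/C(=C\c3cc(OC)cc(OC)c3)C2=O)cc(OC)c1` gives 11400 nM and compound 2 `CC(=O)Nc1ccc(S(=O)(=O)N2C/C(=C\c3cccc([N+](=O)[O-])c3)C(=O)/C(=C/c3cccc([N+](=O)[O-])c3)C2)cc1` gives 6760 nM, so these two values lie within the scatter of each other. Compound 3 `COc1cc(/C=C2\CN(S(=O)(=O)c3ccc(F)cc3)C/C(=C\c3ccccc3F)C2=O)cc(OC)c1` carries 2-fluorophenyl in place of 3,5-dimethoxyphenyl on a double-bonded chain carbon bound to a double-bonded ring carbon. For the measured compounds named here, no measured pair shows a change of this kind, so the expectation is tentative. The expected step in this assay is small and towards a lower number, a 1.9-fold lower number from compound 1 to compound 3 (0.28 log units; within the scatter). For compound 3 the estimated value is 6000 nM, with an expected range of 2000 nM to 16000 nM.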

Compound 3, half-maximal inhibitory concentration: 14000 nM
For compound 3 the middle estimate is 2.3-fold (0.37 log units) below the measured one; measured number inside the range.
By their numbers in this assay, from the lowest: compounds 2, 1 and 3 (each within the scatter of the next, the first and the last beyond it).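

Placing 2-fluorophenyl in place of 3,5-dimethoxyphenyl on a double-bonded chain carbon bound to a double-bonded ring carbon gives a 1.2-fold higher number from compound 1 to compound 3 (0.09 log units; within the scatter) in this assay. For the compounds shown here, this is the first single-place comparison, and it shows that two aryl groups differing in heavy atoms and hydrogen-bond acceptors cannot be told apart at this position. No measurement shown here offers an explanation for this result.

From the compounds shown here alone, whether an amine or a carboxylic acid on this aryl ring would leave the number within the scatter remains open. So does the effect of a single exchange at the second arylidene group of the shared core.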